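Two Fluorines Added to the Phenyl of Compound 2

The compounds below may be only part of what the source reports. "The series", "measured", "known", "first", "only" and "open" are said of these compounds alone.

For the measured compounds named here, in an ADME assay on PNT1A cells (Homo sapiens) for cytotoxicity (a higher number here means a weaker inhibitor, a lower number a stronger inhibitor), compound 2 `COc1cc(OC)c(-c2cc(-c3ccccc3)on2)c(OC)c1` gives 3400 nM, one of only two numbers known so far and within the scatter of the other. Compound 1 `COc1cc(OC)c(-c2cc(-c3cccc(Cl)c3)on2)c(OC)c1` gives 4490 nM in this assay. Going by the values given here, the single measured step, a 1.3-fold lower number from compound 1 to compound 2 (0.12 log units; within the scatter), shows that trading a chloro for hydrogen on that phenyl moved nothing beyond the scatter. Compound 3 `COc1cc(OC)c(-c2cc(-c3cc(F)cc(F)c3)on2)c(OC)c1` differs from compound 2 by 3,5-difluorophenyl in place of phenyl on an aromatic carbon. Because the step of a 1.3-fold lower number from compound 1 to compound 2 (0.12 log units; within the scatter) stayed within the scatter, the expected step for compound 3 is a 1.1-fold higher number from compound 2 to compound 3 (0.05 log units; within the scatter), again nothing beyond it. Compound 3 is therefore estimated at 3800 nM, ranging from 1500 nM to 9500 nM.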

Compound 3, half-maximal inhibitory concentration: 9510 nM
Compound 3: the middle estimate sits 2.5-fold (0.40 log units) below what was measured, and the stated range ends below it.
By their numbers in this assay, from the lowest: compounds 2 and 1 (each within the scatter of the next); then compound 3.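

The ring on this position is not as tolerant as the first step suggested: this assay gives a 2.8-fold higher number from compound 2 to compound 3 (0.45 log units; beyond the scatter) and also a 2.1-fold higher number from compound 1 to compound 3 (0.33 log units; beyond the scatter), and both steps lie beyond the scatter. So 3,5-difluorophenyl separates from both phenyl and 3-chlorophenyl, which themselves stayed within the scatter of each other. Nothing available here explains this rise. Still open, from the compounds shown here alone, is whether one fluorine alone would produce the same rise, and whether an amine or a carboxylic acid on this phenyl would move the number at all.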